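Thioester in place of methyl ester on the conjugated chain

This account rests on a few compounds, and the source may have more. Where it says the series, first, only, none or still open, it means among the compounds named here.

Compound 1 `COC(=O)/C=C(C)/C=C/CC(C)CCCC(C)C` gives 6.2 in a physicochemical assay for lipophilicity (on this read-out lower numbers stand for lower lipophilicity and higher numbers for higher lipophilicity), the second highest of the three numbers: compound 2 `COC(=O)/C=C(C)/C=C/CC(C)CCCC(C)(C)OC` gives 5, compound 3 `CCOC(=O)/C=C(C)/C=C/CC(C)CCCC(C)CC` gives 7.81. Within the data shown here, the single measured step, a number 1.20 log units lower from compound 1 to compound 2 (beyond the scatter), concerns a different part of the chain and bears on the present change only as a gauge of scale. Compound 4 `CSC(=O)/C=C(C)/C=C/CC(C)CCCC(C)C` differs from compound 1 by methylsulfanyl in place of methoxy on a carbonyl carbon. Among the measured compounds shown here, no measured pair shows this exchange, so the expectation rests on the general run of such swaps, which points upward and is expected to move beyond the scatter, a number 0.60 log units higher from compound 1 to compound 4 (beyond the scatter). Compound 4 is therefore estimated at 6.8, with a range from 6.3 to 7.3.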

Compound 4, partition coefficient: 7.44
Compound 4: the middle estimate sits 0.64 log units below what was measured; measured number above the stated range.
By their numbers in this assay, from the lowest: compound 2; then compound 1; then compound 4; then compound 3.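

At the carbonyl carbon, methylsulfanyl in place of methoxy gives a number 1.24 log units higher from compound 1 to compound 4 (beyond the scatter) in this assay and shows that this end of the chain, which the earlier step left unchanged, can carry a large change on this read-out. The direction is opposite to that of the large step on the saturated chain, a number 1.20 log units lower from compound 1 to compound 2 (beyond the scatter), so the two sites move the number in opposite directions for these two changes. No measurement shown accounts for the size of the new step.

As far as these compounds go, it remains open whether methylsulfanyl gives a step of this size on the chain of compound 2. Also open, from the compounds shown here alone, is where a methylamino group on the carbonyl carbon would fall on this read-out.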